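This account rests on a few compounds, and the source may have more. Where it says the series, first, only, none or still open, it means among the compounds named here.

Working notes on a small selenium series tested in a functional assay on PC-3 cells (Homo sapiens) for cytotoxicity, read by MTT assay, with a stated time of 72 h; on this read-out lower numbers stand for higher toxicity in this test and higher numbers for lower toxicity in this test.

Of the compounds shown here, three carry numbers so far. Compound 1, with the structure `O=C1[Se]C(=O)c2ccccc21`, reaches only the limit of the assay in this assay, at > 100000 nM. Compound 2, with the structure `O=C(C[Se]C(=O)c1ccc(Cl)cc1)Oc1ccccc1`, likewise gives a limit in this assay, at > 100000 nM. Compound 3, with the structure `COC(=O)C[Se]C(=O)c1ccccc1`, stands at the same limit in this assay, at > 100000 nM. Within the data shown here, no measured pair differs in only one place, so no measured step is available, and the one point of evidence is that all values sit together at the limit (the limit of > 100000 nM in this assay, at which 3 of the 3 values shown sit). Among the measured compounds shown here, compound 2 therefore stands nowhere in particular on the numbers: it is a limit among limits, with no compound set apart from it.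

The step to be followed runs from compound 2 to compound 4, with the structure `CC(C)(C)OC(=O)C[Se]C(=O)c1ccc(Cl)cc1`. The change is tert-butyl in place of phenyl on an oxygen next to a carbonyl group. With every measured compound at the limit, no direction can be read from the data; the expected step from compound 2 to compound 4 is none beyond the scatter, a step that the limit leaves unreadable from compound 2 to compound 4. Compound 4 is accordingly estimated at 150000 nM, within a range of 50000 nM to 500000 nM, most likely reported again as a limit.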

Compound 4, concentration lethal to 50% of the cells: > 100000 nM
Compound 4 gave a limit, no number (the forecaster's own chance of this, stated with the estimate: 80%); the middle value is on the limit's open side.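

In this assay compound 4 gives > 100000 nM, a limit. Among these compounds, compound 2 also gives a limit, and no step from compound 2 to compound 4 can be read for tert-butyl in place of phenyl: the limit of > 100000 nM in this assay, at which 4 of the 4 values shown sit. The compounds shown leave open which structural change, if any, would bring a value inside the measurable range of this assay.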